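The source may report more compounds than this note shows. Statements on the series, on what has been measured and on what is new or still open speak of the compounds shown alone.

Measured compounds:
Compound 1, `COc1ccccc1CC(C)(Oc1ccc(C(C)C)cc1)C(=O)O`, gives > 10 mg/kg.
Compound 2, `COc1ccc(CC(C)(Oc2ccc(C(C)C)cc2)C(=O)O)cc1`, gives > 10 mg/kg.
Compound 3, `CC(C)c1ccc(OC(C)(Cc2ccccc2-c2ccccc2)C(=O)O)cc1`, gives 10 mg/kg.

In a functional assay on the whole organism for inhibition, with Rattus norvegicus as the target (a lower number here means that less compound is needed, a higher number that more compound is needed for the effect), the value of compound 1 is a limit of the assay, not a number. The value of compound 2 is likewise a limit. Compound 3 is the only one of the three with a measured number, 10 mg/kg. The two cores differ as 4-methoxyphenyl in place of 2-methoxyphenyl on a saturated chain carbon, two bonds along the chain from a carbonyl carbon and an oxygen on an aromatic ring, and the step between them is a step that the two limits leave unreadable from compound 1 to compound 2. The change phenyl in place of methoxy on an aromatic carbon gives a number no higher from compound 1 to compound 3 (the limit leaves the size open); the limit of > 10 mg/kg in this assay, at which 2 of the 3 values shown sit, is the reason its size stays open.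

Compound 4, `CC(C)c1ccc(OC(C)(Cc2ccc(-c3ccccc3)cc2)C(=O)O)cc1`, has not yet been measured in this assay. It differs from compound 2 by phenyl in place of methoxy on an aromatic carbon, the same kind of change as from compound 1 to compound 3, but the place differs: ortho to a large group in compound 3, para to a large group in compound 4. Compound 4 is expected to show a step of a number no higher from compound 2 to compound 4 (the limit leaves the size open), resting on a number no higher from compound 1 to compound 3 (the limit leaves the size open), since compound 2 sits at the limit of > 10 mg/kg in this assay, at which 2 of the 3 values shown sit, as compound 1 does. Compound 4 is estimated at 10 mg/kg, between 3 mg/kg and 30 mg/kg.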

Compound 4, dose for half-maximal effect: 1 mg/kg
Compound 4: middle estimate off by 10-fold (1.00 log units), on the high side, outside the stated range (below it).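

In this assay, phenyl in place of methoxy on an aromatic carbon, para to a large group, gives an at least 10-fold lower number from compound 2 to compound 4 (1.00 log units; beyond the scatter). Set beside the same change on the other core, the comparison remains undecided: the same change on two cores in this assay, a number no higher (the limit leaves the size open) from compound 1 to compound 3 and an at least 10-fold lower number (1.00 log units; beyond the scatter) from compound 2 to compound 4; the limit leaves it open whether they differ. The two results show that the change did not raise the number on either core and brought a clear drop on the core of compound 2, but they do not show how far the size of that drop carries from one core to another, and the starting points of both steps stand at a limit: the limit of > 10 mg/kg in this assay, at which 2 of the 4 values shown sit.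

The compounds shown leave open whether the lower number is specific to phenyl or would also follow from another group in the same place, such as a cyclohexyl or a benzyloxy group. They also leave open how compound 4 would respond if its carboxylic acid gave way to an amide or its isopropyl group to a longer chain.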